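Oxadiazole sulfonamides: methoxy to ethoxy at the aryl ether

The compounds below may be only part of what the source reports. "The series", "measured", "known", "first", "only" and "open" are said of these compounds alone.

Measured so far:
compound 1, `CCOc1ccc(Cc2nnc(CN(c3ccccc3CC)S(=O)(=O)c3ccc(C)cc3)o2)cc1`, 39.8 nM
compound 2, `COc1ccc(Cc2nnc(CN(c3cccc(Cl)c3C)S(=O)(=O)c3ccc(C)cc3)o2)cc1`, 39.8 nM

In a functional assay on CHO cells for antagonist activity at prostaglandin E2 receptor EP1 subtype (Homo sapiens), read by FLIPR and calcium flux (a lower number here means a stronger inhibitor, a higher number a weaker inhibitor), compound 1 gives 39.8 nM. In this assay compound 2 gives 39.8 nM, level with compound 1 at the digits recorded; the two values lie within the scatter of each other, so no order between them is claimed. Among the measured compounds shown here, compounds 1 and 2 differ in more than one place, so their pair gives no single-point step.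

The next compound is compound 3, `CCOc1ccc(Cc2nnc(CN(c3cccc(Cl)c3C)S(=O)(=O)c3ccc(C)cc3)o2)cc1`, not yet measured in this assay. It differs from compound 2 by methyl in place of hydrogen on a saturated chain carbon bound to an oxygen on an aromatic ring. For the measured compounds named here, no measured pair isolates this change. Compound 1 already carries the ethoxy and sits level with compound 2, which is the only hint available; it does not isolate the change either.

Expectation: a step from compound 2 to compound 3 of no size beyond the scatter, in either direction, is estimated, a 1.1-fold lower number from compound 2 to compound 3 (0.04 log units; within the scatter). Compound 3 is therefore estimated at 36 nM in this assay, with a range from 15 nM to 90 nM.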

Compound 3, inhibition constant: 50.1 nM
Beside the measured number, compound 3's estimate is 1.4-fold (0.14 log units) below it; the measured number falls inside the stated range.
By their numbers in this assay, from the lowest: compounds 1, 2 and 3 (each within the scatter of the next).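

In this assay, among the compounds shown here, the first one-place reading at this aryl ether is a 1.3-fold higher number from compound 2 to compound 3 (0.10 log units; within the scatter), so with 3-chloro-2-methylphenyl held on the sulfonamide nitrogen, methoxy and ethoxy cannot be told apart. For the compounds shown here, the ethoxy compounds also give a first one-place reading on the sulfonamide nitrogen (a 1.3-fold higher number from compound 1 to compound 3 (0.10 log units; within the scatter)), and 3-chloro-2-methylphenyl and 2-ethylphenyl cannot be told apart there either, a comparison the pair of compound 1 and compound 2 could not provide. No measurement is available that would explain either result.

Going by these compounds alone, these two steps cover only one small change at each of the two places, so it remains open whether a longer chain such as propoxy, a branched isopropoxy group, or a chain ending in an amine or a carboxylic acid would also stay within the scatter at the aryl ether. On these data alone, it also remains open whether methyl in place of hydrogen at this carbon would read the same with 2-ethylphenyl on the sulfonamide nitrogen, and whether the series reads the same in any other measurement.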